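Swapping furan for thiophene on the vinyl arm

A few compounds are considered here, and "the series" means these few. Any claim that something is new, unique, unknown or untested is made for them only; others in the source may bear on it.

Measured so far:
- Compound 1, `Nc1nc(/C=C/c2ccccc2)c2ncn(Cc3ccccc3)c2n1`: 91%
- Compound 2, `C(=C/c1nc(-c2ccccc2)nc2c1ncn2Cc1ccccc1)\c1ccccc1`: 34%
- Compound 3, `C(=C/c1[nH]cnc2ncnc1-2)\c1ccco1`: 24%

These three compounds were tested in a functional assay on K562 cells (Homo sapiens) for inhibition, read by thymidine incorporation, with a stated time of 48 h, tested at 10 ug/mL; a higher number here means more inhibition at the concentration tested (going by the name of the read-out), a lower number less inhibition. In that assay compound 1 gives 91%, while compound 2 gives 34%. Among the compounds with values here, the one measured single-point change, a number 57 percentage points lower from compound 1 to compound 2 (beyond the scatter), is the only step available. Compound 3 gives 24%, which is far below compound 1 and close to compound 2, with the gap to compound 2 lying within the usual scatter.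

Compound 4, `C(=C/c1[nH]cnc2ncnc1-2)\c1ccsc1`, is not yet measured. It differs from compound 3 by thiophen-3-yl in place of furan-2-yl on a double-bonded chain carbon bound to a double-bonded chain carbon. Within the data shown here, no measured step touches this part of the molecule: the one step known concerns the amino group on the shared core, not the five-membered ring on the chain, so it gives no guidance here. With nothing to suggest a shift, the expectation is a step of about a number 1 percentage points higher from compound 3 to compound 4 (within the scatter) in this assay, not beyond the scatter. Compound 4 is therefore estimated at 25%, within a range from 8% to 45%.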

Compound 4, a percentage reported as inhibition, at one concentration (the size of the read-out at that concentration, not a potency): 32%
Beside the measured number, compound 4's estimate is 7 percentage points below it, within the range that was stated.
By their numbers in this assay, from the lowest: compounds 3, 4 and 2 (each within the scatter of the next); then compound 1.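

In this assay, within the data shown here, placing thiophen-3-yl in place of furan-2-yl on a double-bonded chain carbon gives a number 8 percentage points higher from compound 3 to compound 4 (within the scatter) and is the first measured step at this position. These two rings have the same counts of heavy atoms, donors and acceptors, with sulfur in one and oxygen in the other, and this exchange produces no readable difference in the assay. No available evidence bears on this result.

On these data alone, it remains open whether a pyridine ring or a carboxylic acid at this position would give a clearly different number. As far as these compounds go, compound 3 and compound 4 each differ from compound 1 in more than one place, so what separates them from compound 1 also remains open.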